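Ethoxymethyl in place of hydroxymethyl: cytotoxicity notes

A few compounds are considered here, and "the series" means these few. Any claim that something is new, unique, unknown or untested is made for them only; others in the source may bear on it.

Series in a functional assay on SK-BR-3 cells (Homo sapiens) for cytotoxicity, read by MTT assay, with a stated time of 72 h; on this read-out lower numbers stand for an effect already at smaller amounts and higher numbers for an effect only at larger amounts of compound:
- Compound 1 `CCOC(=O)c1c(C)coc1-c1ccc2c(CC)cccc2c1OC`: 2.5 ug/mL
- Compound 2 `CCc1cccc2c(OC)c(-c3occ(C)c3CO)ccc12`: 0.73 ug/mL
- Compound 3 `CCOCc1c(C)coc1-c1ccc2c(CC)cccc2c1OC`: not yet measured

Compound 2 holds the lower of the two numbers. The next change is ethyl in place of hydrogen on an oxygen on a saturated carbon, hydroxymethyl to ethoxymethyl. Within the data shown here, one measured step bears on it: a 3.4-fold lower number from compound 1 to compound 2 (0.53 log units; beyond the scatter), hydroxymethyl in place of ethoxycarbonyl on an aromatic carbon. Compound 3, like compound 1, has no hydroxy hydrogen, so a modest move back towards higher numbers is expected in this assay. The expected step is a 2.2-fold higher number from compound 2 to compound 3 (0.34 log units; beyond the scatter). The estimate for compound 3 is 1.6 ug/mL, with an expected range of 0.6 ug/mL to 4.5 ug/mL.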

Compound 3, concentration for half-maximal effect: > 10 ug/mL
Compound 3: a limit, no number; the forecaster's own chance of this, stated with the estimate: 3%; middle value at least 6.2-fold (0.79 log units) away from the limit.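

On this position, ethyl in place of hydrogen on the oxygen of hydroxymethyl gives an at least 13-fold higher number from compound 2 to compound 3 (1.13 log units; beyond the scatter) in this assay, so the group tolerates far less change here than the earlier pair suggested. Having no hydroxy hydrogen does not by itself put compound 3 level with compound 1, as ethoxymethyl in place of ethoxycarbonyl gives an at least 4.0-fold higher number from compound 1 to compound 3 (0.60 log units; beyond the scatter) on the same carbon. The reading for compound 3 is a limit, not a number: the limit of > 10 ug/mL in this assay, at which 1 of the 3 values shown sits.

Going by these compounds, whether the size of the ethyl or the capping of the oxygen governs this stays open. Methoxymethyl, an amine or a carboxylic acid at this place would bear on that.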